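The compounds below may be only part of what the source reports. "The series", "measured", "known", "first", "only" and "open" are said of these compounds alone.

Working notes on a short series of compounds sharing one core, each carrying a differently substituted benzene ring on the imine. In a functional assay on DLD-1 cells (Homo sapiens) for cytotoxicity, read by MTT assay, with a stated time of 72 h (a lower number here means a stronger inhibitor, a higher number a weaker inhibitor), compound 1, `CCOc1cccc(/C=N/c2c(C)n(C)n(-c3ccccc3)c2=O)c1`, gives 724000000 nM. Compound 2, `COc1ccc(/C=N/c2c(C)n(C)n(-c3ccccc3)c2=O)cc1OC`, gives 676000000 nM in this assay, and compound 3, `COc1ccccc1/C=N/c1c(C)n(C)n(-c2ccccc2)c1=O`, gives 933000000 nM. Compound 1 sits second highest of the three numbers; its nearest neighbour is compound 2, whose number lies within the scatter of it, and the furthest is compound 3, also within the scatter. Among the compounds with values here, the three values therefore cannot be ordered against one another, and no step between measured compounds is available to calibrate the effect of a change on the substituted ring.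

The next compound, compound 4, `Cc1c(/N=C/c2cccc([N+](=O)[O-])c2)c(=O)n(-c2ccccc2)n1C`, differs from compound 1 in one place: nitro in place of ethoxy on an aromatic carbon. Since the three measured substitution patterns on that ring all sit within the scatter of each other, no direction is expected for this exchange, and the step is expected to stay within the scatter. The expected step of a 1.0-fold lower number from compound 1 to compound 4 (0.00 log units; within the scatter) reflects this. Compound 4 is therefore expected to give 720000000 nM in this assay, with a range from 360000000 nM to 1450000000 nM.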

Compound 4, half-maximal inhibitory concentration: 490000000 nM
Compound 4: middle estimate off by 1.5-fold (0.17 log units), on the high side; the range from low to high includes it.
By their numbers in this assay, from the lowest: compounds 4, 2, 1 and 3 (each within the scatter of the next).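

In this assay, within the data shown here, nitro in place of ethoxy on an aromatic carbon, meta to a large group, gives the first step that can be read: a 1.5-fold lower number from compound 1 to compound 4 (0.17 log units; within the scatter). Ethoxy and nitro have the same count of heavy atoms but differ in their atoms and hydrogen-bond acceptors, and this exchange at this position still produces no change beyond the scatter, so the flat picture left by the three earlier values now rests on one direct comparison. No measurement in hand bears on why the exchange leaves the number within the scatter.

Going by these compounds, whether an amine, a carboxylic acid or a longer alkoxy chain at this position would move the number beyond the scatter remains open, since a single step within the scatter says little about groups of another kind. On these data alone, it is also open whether nitro would behave in the same way at another place on this benzene ring, or whether any change to the shared core would shift the values more than changes on this ring do.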